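The source may hold more compounds than are shown below. What is called first, only, known or untested is meant among the compounds shown, and "the series" means these compounds.

Compound 1 `COc1ccc(C(=O)Nc2cc3nc(C4CCCCC4)[nH]c3cc2N2CCCC2)cc1`: in an ADME assay on Vero cells (Chlorocebus sabaeus) for cytotoxicity, read by resazurin assay, with a stated time of 3 days (a higher number here means a weaker inhibitor, a lower number a stronger inhibitor), compound 1 gives > 100 ug/mL, which is a limit of the assay rather than a number.
Compound 2 `O=C(Nc1cc2nc(C3CCCCC3)[nH]c2cc1N1CCCC1)c1ccccc1`: in this assay compound 2 gives > 100 ug/mL, again a limit and not a number.

Compound 2 therefore stands where every value shown so far stands, namely at the limit of > 100 ug/mL in this assay, at which 2 of the 2 values shown sit. For the measured compounds named here, the only measured step, a step that the two limits leave unreadable from compound 1 to compound 2, is unreadable: both of its ends are limits, so neither its size nor its direction can be taken from the data. Compound 3 `CCCCNC(=O)Nc1cc2nc(C3CCCCC3)[nH]c2cc1N1CCCC1` has not yet been measured. Its change from compound 2 is butylamino in place of phenyl on a carbonyl carbon, that is, a benzoyl group becomes a butylcarbamoyl group and the benzamido substituent becomes a (butylcarbamoyl)amino substituent. Going by the values given here, no measured step touches this part of the molecule, and the single step that exists tells nothing, so the data give no size or direction to build on. The step of a number no higher from compound 2 to compound 3 (the limit leaves the size open) is therefore expected to be nothing beyond the scatter. Compound 3 is expected in this assay to reach again only the limit, estimated at 100 ug/mL, with a range from 40 ug/mL to 250 ug/mL.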

Compound 3, half-maximal inhibitory concentration: > 100 ug/mL
Compound 3 ended at the assay's limit; the forecaster's own chance of this, stated with the estimate: 75%; the middle value sits exactly at the limit.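

No new step can be read in this assay. Compound 1, compound 2 and compound 3 all end at the same limit, so neither the size nor the direction of any step among them is available: the limit of > 100 ug/mL in this assay, at which 3 of the 3 values shown sit.

The compounds shown leave open how far each lies from that limit, and whether phenyl, 4-methoxyphenyl or butylamino on the carbonyl carbon makes any difference.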